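This account rests on a few compounds, and the source may have more. Where it says the series, first, only, none or still open, it means among the compounds named here.

In an ADME assay on the whole organism (strain CD-1) for pharmacokinetics, with Mus musculus as the target, at a dose of 10 mg/kg by the oral route (on this read-out higher numbers stand for higher exposure at the dose given and lower numbers for lower exposure), two compounds have been measured so far:
Compound 1, `CC/C(=C(/c1ccc(/C=C/C(=O)O)cc1)c1ccc2[nH]ncc2c1)c1ccccc1`: 5800 ng.h/mL
Compound 2, `CC/C(=C(/c1ccc(/C=C/C(=O)O)cc1)c1ccc2[nH]ncc2c1Cl)c1ccccc1`: 18000 ng.h/mL

Going by the values given here, compound 2 stands highest of the two numbers; its only neighbour is compound 1, and the single measured step between them, a 3.1-fold higher number from compound 1 to compound 2 (0.49 log units; beyond the scatter), lies beyond the usual scatter. The unmeasured compound 3, `CC/C(=C(/c1ccc(/C=C/C(=O)O)cc1)c1ccc2[nH]ncc2c1C#N)c1ccccc1`, differs from compound 2 in one place: cyano in place of chloro on an aromatic carbon. Among the compounds with values here, that step from compound 1 to compound 2 is the only guide available, and it concerns hydrogen giving way to chloro, not chloro giving way to cyano, so it bears on the new change only loosely. Nothing measured here covers a cyano group at all. On that thin basis, the expected step of a 2.0-fold lower number from compound 2 to compound 3 (0.30 log units; within the scatter) is a modest drop back toward the lower of the two measured numbers, small enough that it may well sit within the scatter. Compound 3 is therefore estimated at 9000 ng.h/mL in this assay, with a range from 3000 ng.h/mL to 25000 ng.h/mL.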

Compound 3, area under the concentration-time curve: 500 ng.h/mL
Estimate against measurement, compound 3: 18-fold (1.26 log units) above, and the stated range ends above it.
By their numbers in this assay, from the lowest: compound 3; then compound 1; then compound 2.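

In this assay, this position proves far more sensitive than the earlier pair suggested: replacing chloro with cyano on the same aromatic carbon gives a 36-fold lower number from compound 2 to compound 3 (1.56 log units; beyond the scatter), a much larger move than the gain of a 3.1-fold higher number from compound 1 to compound 2 (0.49 log units; beyond the scatter) seen when chloro replaced hydrogen. Cyano also does more than cancel that gain, since its comparison with hydrogen gives a 12-fold lower number from compound 1 to compound 3 (1.06 log units; beyond the scatter), so the two groups push exposure in opposite directions from the same place on the shared core. No supporting measurement is available to explain this sharp difference between two small groups.

As far as these compounds go, with only hydrogen, chloro and cyano compared at this carbon, it remains open whether chloro or cyano is the unusual case, and a fluoro, methyl or methoxy group there would help to settle that. From the compounds shown here alone, a single exposure number also cannot separate how much of a compound is absorbed from how quickly it is removed, so the stage at which compound 3 loses exposure remains unknown.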